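Amino to fluoro on the pendant ring: cytotoxicity outlook

The source may hold more compounds than are shown below. What is called first, only, known or untested is meant among the compounds shown, and "the series" means these compounds.

Going by the values given here, compound 2 `Cc1cc(C#N)cc(C)c1Oc1nc(Nc2ccc(C#N)cc2)ncc1-c1ccc(N)cc1` gives 310 nM in an ADME assay on MT4 cells (Homo sapiens) for cytotoxicity, read by MTT assay, with a stated time of 5 days (on this read-out higher numbers stand for lower toxicity in this test and lower numbers for higher toxicity in this test), the lowest of the two numbers measured so far; compound 1 `Cc1ccc(-c2cnc(Nc3ccc(C#N)cc3)nc2Oc2c(C)cc(C#N)cc2C)cc1` gives 26100 nM. Compound 3 `Cc1cc(C#N)cc(C)c1Oc1nc(Nc2ccc(C#N)cc2)ncc1-c1ccc(F)cc1` differs from compound 2 by fluoro in place of amino on an aromatic carbon. Among the compounds with values here, the one step that bears on this is an 84-fold lower number from compound 1 to compound 2 (1.93 log units; beyond the scatter), the entry of the amino; compound 3 takes it out again and carries fluoro, which like the methyl of compound 1 brings no hydrogen-bond donor or acceptor. For compound 3 a large rise is expected, a 48-fold higher number from compound 2 to compound 3 (1.68 log units; beyond the scatter). Compound 3 is estimated at 15000 nM, range 3000 nM to 60000 nM.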

Compound 3, half-maximal cytotoxic concentration: 42700 nM
Estimate against measurement, compound 3: 2.8-fold (0.45 log units) below, within the range that was stated.
By their numbers in this assay, from the lowest: compound 2; then compounds 1 and 3 (each within the scatter of the next).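

In this assay the step of a 140-fold higher number from compound 2 to compound 3 (2.14 log units; beyond the scatter) comes with fluoro in place of amino, and the step of a 1.6-fold higher number from compound 1 to compound 3 (0.21 log units; within the scatter) comes with fluoro in place of methyl. Among these three groups on the aromatic carbon para to a large group, only amino goes with the low number, while fluoro and methyl are not told apart. Nothing measured here accounts for the amino result.

Open, as far as these compounds go, is whether hydroxy, methoxy or dimethylamino at this position would go with the low number of compound 2 or with the high numbers of compound 1 and compound 3.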